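The source may report more compounds than this note shows. Statements on the series, on what has been measured and on what is new or still open speak of the compounds shown alone.

Working notes on the series. In an ADME assay on liver (Homo sapiens) for metabolic stability, read by LC-MS, using S9 fraction and NADPH, with a stated time of 45 min, tested at 1 uM (on this read-out lower numbers stand for a shorter-lived compound and higher numbers for a longer-lived compound), compound 3 `Cc1cc(/C=C/C#N)cc(C)c1Oc1cc(Nc2ccc(C#N)cc2)c(N)cc1C(=O)N1CC1` gives 1.83 h, the highest of the three numbers measured. Compound 1 `Cc1cc(/C=C/C#N)cc(C)c1Oc1cc(Nc2ccc(C#N)cc2)c(N)cc1C(=O)NN` gives 0.65 h in this assay, and compound 2 `Cc1cc(/C=C/C#N)cc(C)c1Oc1cc(Nc2ccc(C#N)cc2)c(N)cc1C(=O)NCCC(F)F` gives 0.233 h; the step of a 2.8-fold lower number from compound 1 to compound 2 (0.45 log units; beyond the scatter) is modest, while a 2.8-fold higher number from compound 1 to compound 3 (0.45 log units; beyond the scatter) and a 7.9-fold higher number from compound 2 to compound 3 (0.90 log units; beyond the scatter) both run upward to compound 3.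

Compound 4 `COC(=O)c1cc(N)c(Nc2ccc(C#N)cc2)cc1Oc1c(C)cc(/C=C/C#N)cc1C` differs from compound 3 by methoxy in place of aziridin-1-yl on a carbonyl carbon, that is, the (aziridin-1-yl)carbonyl becomes a methoxycarbonyl. For the measured compounds named here, the steps that bear on this are the two in which the group on that carbonyl carbon was exchanged, a 2.8-fold higher number from compound 1 to compound 3 (0.45 log units; beyond the scatter) and a 7.9-fold higher number from compound 2 to compound 3 (0.90 log units; beyond the scatter): each exchange moved this assay by a modest amount, and the step into compound 3 was the largest gain seen. Going by the values given here, no measured step replaces the amide-type nitrogen with an oxygen, so the direction is uncertain; a modest downward step from the highest number in the set is the more likely outcome, with the range kept wide. For compound 4 in this assay the expected step is a 2.0-fold lower number from compound 3 to compound 4 (0.31 log units; beyond the scatter), which means an estimated value of 0.9 h, between 0.3 h and 2.5 h.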

Compound 4, half-life in the liver assay: 0.128 h
Estimate against measurement, compound 4: 7.0-fold (0.85 log units) above; the measured number lies below the stated range.
By their numbers in the liver assay, from the lowest: compounds 4 and 2 (each within the scatter of the next); then compound 1; then compound 3.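

In the liver assay the exchange at this carbonyl carbon produces the largest step in the series (a 14-fold lower number from compound 3 to compound 4 (1.16 log units; beyond the scatter)), so the high number of compound 3 (1.83 h) does not survive methoxy in place of aziridin-1-yl. Methoxy in place of the other two groups gives (a 5.1-fold lower number from compound 1 to compound 4 (0.71 log units; beyond the scatter)) and (a 1.8-fold lower number from compound 2 to compound 4 (0.26 log units; within the scatter)), which places the methoxycarbonyl at the low end of the series alongside the (3,3-difluoropropyl)amino amide, so a nitrogen on the carbonyl carbon does not by itself give a high number, as compound 2 shows. In a physicochemical assay for solubility, read by HPLC, in phosphate buffer, with a stated time of 4 h, at pH 7.4 (on this read-out higher numbers stand for higher solubility and lower numbers for lower solubility), compound 3 gives 1.2 ug/mL and compound 4 gives 1.21 ug/mL, and the same exchange gives (a 1.0-fold higher number from compound 3 to compound 4 (0.00 log units; within the scatter)), so the two read-outs part for this pair.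

Going by these compounds, whether a carboxylic acid, a dimethylamino group or an azetidin-1-yl group on this carbonyl carbon would hold the number of compound 3 stays open. No measurement at hand accounts for these steps.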